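The source may report more compounds than this note shows. Statements on the series, on what has been measured and on what is new or still open speak of the compounds shown alone.

Measured compounds:
- Compound 1, `ClCc1ccccc1Cn1cnc2c(Cl)nc(Cl)nc21`: 2810 nM
- Compound 2, `ClCc1ccc(Cn2cnc3nc(Cl)nc(Cl)c32)cc1`: 4070 nM

Both compounds were tested in a functional assay on OVCAR-8 cells (Homo sapiens) for cytotoxicity, read by sulforhodamine B assay, with a stated time of 48 h; on this read-out higher numbers stand for weaker inhibition of growth and lower numbers for stronger inhibition of growth. Compound 1 gives the lower of the two numbers, but compound 2 lies within the usual scatter of it, so the two cannot be told apart on this read-out.

Compound 3, `Nc1nc(Cl)c2ncn(Cc3ccccc3CCl)c2n1`, has not yet been measured. It differs from compound 1 by amino in place of chloro on an aromatic carbon, that is, an amino group in place of a chloro group on an aromatic carbon of the shared core, at a carbon that sits between two ring nitrogen atoms. For the measured compounds named here, no pair among the measured compounds shows this change, so its effect can only be guessed. A modest weakening of growth inhibition is expected for compound 3, with the step of a 1.6-fold higher number from compound 1 to compound 3 (0.20 log units; within the scatter) likely staying close to the scatter. Compound 3 is expected to give about 4500 nM, within a range of 1500 nM to 14000 nM.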

Compound 3, concentration for total growth inhibition: 19500 nM
Compound 3: the middle estimate sits 4.3-fold (0.64 log units) below what was measured; measured number outside the range, above it.
By their numbers in this assay, from the lowest: compounds 1 and 2 (each within the scatter of the next); then compound 3.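

In this assay, the aromatic carbon between two ring nitrogen atoms proves sensitive to substitution: an amino group in place of the chloro group gives a 6.9-fold higher number from compound 1 to compound 3 (0.84 log units; beyond the scatter), so growth inhibition weakens. For the compounds shown here, this is the first step between measured compounds that can be read, and it shows that the chloro group at this place cannot be exchanged for an amino group without a change beyond ordinary assay variation. Nothing available explains why the number rises.

Going by these compounds, whether this weakening is specific to the amino group stays open, since a methoxy group, a methyl group or a hydrogen at the same carbon might behave differently. On these data alone, it is also open whether an amino group in place of the remaining chloro group on the shared core would give a step of similar size.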